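Swapping bromo for trifluoromethoxy on a shared core

The source may report more compounds than this note shows. Statements on the series, on what has been measured and on what is new or still open speak of the compounds shown alone.

Compound 3 `CNC(=O)c1cc(Oc2ccc3nc(Nc4cccc(Br)c4)ncc3c2)ccn1`, compound 1 `CNC(=O)c1cc(Oc2ccc3nc(Nc4ccccc4)ncc3c2)ccn1` and compound 2 `CNC(=O)c1cc(Oc2ccc3nc(Nc4cccc(C(C)(C)C)c4)ncc3c2)ccn1` share one core and were run in an ADME assay on Caco-2 cells (Homo sapiens) for permeability, in the apical to basolateral direction; on this read-out lower numbers stand for lower permeability and higher numbers for higher permeability. In this assay compound 3 gives < 1 10^-6 cm/s, which is a limit of the assay rather than a number. Compound 1 likewise reads < 1 10^-6 cm/s, a limit. Compound 2 also reads < 1 10^-6 cm/s, again a limit. Compound 3 thus stands at the limit of < 1 10^-6 cm/s in this assay, at which 3 of the 3 values shown sit. The steps a step that the two limits leave unreadable from compound 1 to compound 3 and a step that the two limits leave unreadable from compound 2 to compound 3 cannot be sized from such readings. Compound 4 `CNC(=O)c1cc(Oc2ccc3nc(Nc4cccc(OC(F)(F)F)c4)ncc3c2)ccn1` carries trifluoromethoxy in place of bromo on an aromatic carbon. Among the compounds with values here, no measured step shows how this change acts, and the known readings set no direction. Compound 4 is expected to remain at the limit, so the estimated step is a step that the limit leaves unreadable from compound 3 to compound 4. The estimate for compound 4 is 0.5 10^-6 cm/s, with a range from 0.1 10^-6 cm/s to 2 10^-6 cm/s.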

Compound 4, apparent permeability: < 1 10^-6 cm/s
Compound 4 gave a limit, no number; the forecaster's own chance of this, stated with the estimate: 75%; the middle value is on the limit's open side.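

In this assay compound 4 also gives only a limit, like compound 1, compound 2 and compound 3, so no step among these four compounds can be read: the limit of < 1 10^-6 cm/s in this assay, at which 4 of the 4 values shown sit. The compounds shown leave open whether hydrogen, tert-butyl, bromo and trifluoromethoxy differ at all in this read-out.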